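This account rests on a few compounds, and the source may have more. Where it says the series, first, only, none or still open, it means among the compounds named here.

Working notes on the series.

Compound 1 `Cc1c(C(=O)Nc2ccc(Oc3ccnc4[nH]ccc34)c(F)c2)nnn1-c1ccccc1F` and compound 2 `Cc1c(C(=O)Nc2ccc(Oc3ccnc4[nH]ccc34)c(F)c2)nnn1-c1ccc(F)cc1` share the core and differ only in the ring on the aromatic nitrogen. In a functional assay on MCF7 cells (Homo sapiens) for cytotoxicity, read by MTT assay, with a stated time of 72 h (a higher number here means a weaker inhibitor, a lower number a stronger inhibitor), compound 1 gives 420 nM. In this assay compound 2 gives 170 nM; the change a 2.5-fold lower number from compound 1 to compound 2 (0.39 log units; beyond the scatter) is modest but beyond the scatter. Compound 3 `Cc1c(C(=O)Nc2ccc(Oc3ccnc4[nH]ccc34)c(F)c2)nnn1-c1ccc(F)c(Cl)c1` belongs to the same set; in this assay compound 3 gives "not determined" (no result reported), so no number is available for it. Among the two numbers available, compound 2 holds the lowest, with compound 1 as its nearest neighbour.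

Compound 4 `Cc1c(C(=O)Nc2ccc(Oc3ccnc4[nH]ccc34)cc2)nnn1-c1ccc(F)cc1` is obtained from compound 2 by the change (hydrogen in place of fluoro on an aromatic carbon). Among the measured compounds shown here, no measured step touches this position; the single measured step from compound 1 to compound 2 concerns the ring on the aromatic nitrogen and offers no direct guide. With the rest of the structure unchanged, no step beyond the scatter is expected in either direction in this assay. The expected step is a 1.2-fold higher number from compound 2 to compound 4 (0.07 log units; within the scatter). Compound 4 is therefore estimated at 200 nM, with a range of 80 nM to 500 nM.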

Compound 4, half-maximal inhibitory concentration: 390 nM
Beside the measured number, compound 4's estimate is 2.0-fold (0.29 log units) below it, and the stated range covers the measured number.
By their numbers in this assay, from the lowest: compound 2; then compounds 4 and 1 (each within the scatter of the next).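

The position on the aromatic carbon, ortho to a large group and meta to a large group, now has its first measured step, and it is not silent. In this assay hydrogen in place of fluoro gives a 2.3-fold higher number from compound 2 to compound 4 (0.36 log units; beyond the scatter), so the loss of this single fluorine counts for as much as a modest step, and the ring on the aromatic nitrogen is no longer the only place shown to move the number. Nothing at hand bears on why this step occurs.

On these data alone, whether another group on this carbon, such as methoxy or an amine, would hold the number of compound 2 or move it further stays open. Also open, as far as these compounds go, is whether the same step would appear with the 2-fluorophenyl ring of compound 1 on the aromatic nitrogen.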